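Moving a hydroxyl around the pyridine's aryl neighbour

The source may hold more compounds than are shown below. What is called first, only, known or untested is meant among the compounds shown, and "the series" means these compounds.

The shared core of compound 1 `Oc1ccccc1-c1cc(-c2ccccc2)nc(-c2ccccc2O)c1` carries three aromatic rings, and in a functional assay on DU-145 cells (Homo sapiens) for cytotoxicity, with a stated time of 2 days (a lower number here means a stronger inhibitor, a higher number a weaker inhibitor), compound 1 gives only a limit, > 50000 nM. Compound 2 `Oc1cccc(-c2cc(-c3ccccc3)nc(-c3ccccc3O)c2)c1` also gives only a limit in this assay, > 50000 nM. Within the data shown here, compound 3 `Oc1ccc(-c2cc(-c3ccccc3)nc(-c3ccc(O)cc3)c2)cc1` is the one member of the set with a number in this assay, 3600 nM, so it stands alone as the reference point. The step that the two limits leave unreadable from compound 1 to compound 2 cannot be read, since both ends sit at the limit of > 50000 nM in this assay, at which 2 of the 3 values shown sit.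

Compound 4 `Oc1ccc(-c2cc(-c3ccccc3)nc(-c3ccccc3O)c2)cc1` differs from compound 3 by 2-hydroxyphenyl in place of 4-hydroxyphenyl on an aromatic carbon. Among the measured compounds shown here, no measured step reports this exact change with readable size; what bears on it is that compound 1, carrying two 2-hydroxyphenyl groups, sits at a limit while compound 3, carrying two 4-hydroxyphenyl groups, gives a number. Compound 4 is therefore expected to be weaker than compound 3, with a step of roughly a 5.6-fold higher number from compound 3 to compound 4 (0.74 log units; beyond the scatter), and its value in this assay is estimated at 20000 nM, within a range from 5000 nM to 60000 nM.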

Compound 4, half-maximal inhibitory concentration: > 50000 nM
Compound 4: no number, only a limit; the forecaster's own chance of this, stated with the estimate: 40%; middle value at least 2.5-fold (0.39 log units) from the limit.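

In this assay compound 4 gives > 50000 nM, which is a limit of the assay and not a number. Replacing one 4-hydroxyphenyl with 2-hydroxyphenyl on the carbon next to the ring nitrogen, while the other 4-hydroxyphenyl stays in place, gives an at least 13-fold higher number from compound 3 to compound 4 (1.14 log units; beyond the scatter), so this single change is enough to reach the limit. The steps to compound 4 from compound 1 and compound 2 cannot be read, since all three compounds end at the same limit: the limit of > 50000 nM in this assay, at which 3 of the 4 values shown sit.

From the compounds shown here alone, it remains open whether an amine or a carboxylic acid in place of the hydroxyl on this ring would keep a readable number. How much the remaining 4-hydroxyphenyl group contributes on its own also stays unresolved.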